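Swapping bromo for cyano on a hydroxamic acid growth inhibitor

The compounds below may be only part of what the source reports. "The series", "measured", "known", "first", "only" and "open" are said of these compounds alone.

Of the compounds shown here, three sharing one core have so far been tested in a functional assay on HCT-15 cells (Homo sapiens) for inhibition, read by sulforhodamine B assay; a higher number here means a weaker inhibitor of growth, a lower number a stronger inhibitor of growth. Compound 1 `CC(C)(C)c1ccc(CCCN2CC=C(CCC(=O)NO)C2=O)cc1` gives 5100 nM. Compound 2 `O=C(CCC1=CCN(Cc2cccc(Br)c2)C1=O)NO` gives 4720 nM. Compound 3 `O=C(CCC1=CCN(Cc2ccc(Cl)cc2)C1=O)NO` gives 4720 nM. Compound 2 stands level with compound 3 at the digits shown, the two together the lowest of the three numbers, and compound 1 differs from compound 2 only within the scatter, so none of the three can be called apart from the others.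

The next compound, compound 4 `N#Cc1cccc(CN2CC=C(CCC(=O)NO)C2=O)c1`, has not yet been measured. Its change from compound 2 is cyano in place of bromo on an aromatic carbon. The change keeps the core and its side chain and alters one group on the six-membered aromatic ring of carbon only.

Among the compounds with values here, no two measured compounds differ in one place, so the measured numbers give no direct guide to the size of such a swap. Since compound 1, compound 2 and compound 3 all fall within the scatter of one another despite carrying different groups on that ring, the step from compound 2 to compound 4 in this assay is expected to be small, probably none beyond the scatter, in either direction. Compound 4 is accordingly estimated at 5000 nM, within the range 2000 nM to 12000 nM, which corresponds to an expected step of a 1.1-fold higher number from compound 2 to compound 4 (0.03 log units; within the scatter).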

Compound 4, concentration for 50% growth inhibition: > 10000 nM
Compound 4 gave a limit, no number (the forecaster's own chance of this, stated with the estimate: 5%); middle value at least 2.0-fold (0.30 log units) away from the limit.
By their numbers in this assay, from the lowest: compounds 2, 3 and 1 (each within the scatter of the next). At a limit, above all of these: compound 4.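

Within the data shown here, this pair gives the first step between compounds that differ in one place, and it shows that this position on the aromatic ring does not tolerate every group equally. In this assay, cyano in place of bromo on an aromatic carbon, meta to a large group, brings an at least 2.1-fold higher number from compound 2 to compound 4 (0.32 log units; beyond the scatter), so a change of a single group at this place is enough to weaken growth inhibition beyond the scatter. Compound 4 gives only a limit of the assay, > 10000 nM, and not a number, so the step marks the least the change can amount to and not its full size: the limit of > 10000 nM in this assay, at which 1 of the 4 values shown sits.

The compounds shown do not tell how much weaker compound 4 really is, nor whether bromo is favourable here or cyano is simply unfavourable. A plain hydrogen, a methoxy group, an amine or a carboxylic acid at the same place would be needed to show which groups this position accepts, and whether the result with cyano is a lone case or part of a wider trend.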